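Thiophene attachment change on the shared core

The source may report more compounds than this note shows. Statements on the series, on what has been measured and on what is new or still open speak of the compounds shown alone.

Two compounds of the series carry numbers in a functional assay on DU-145 cells (Homo sapiens) for cytotoxicity, read by CCK-8 assay; a higher number here means a weaker inhibitor, a lower number a stronger inhibitor. Compound 1 `Oc1cccc(-c2cc(-c3cccs3)cc(-c3ccccc3O)n2)c1` gives 9300 nM in this assay. Compound 2 `Oc1ccc(-c2cc(-c3cccs3)cc(-c3cccc(O)c3)n2)cc1` gives 1890 nM in this assay. Among the measured compounds shown here, compound 1 thus stands at the highest of the two numbers, with compound 2 as its only neighbour. For the measured compounds named here, the single measured step is a 4.9-fold lower number from compound 1 to compound 2 (0.69 log units; beyond the scatter), and it concerns 4-hydroxyphenyl in place of 2-hydroxyphenyl on an aromatic carbon.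

Compound 3 `Oc1cccc(-c2cc(-c3ccsc3)cc(-c3ccccc3O)n2)c1` is not yet measured. It differs from compound 1 as follows: thiophen-3-yl in place of thiophen-2-yl on an aromatic carbon. Both hydroxyphenyl groups stay as they are in compound 1; only the thiophene ring is altered. Going by the values given here, no measured step touches the thiophene, so the one known step gives no direct guide to this change; it shows only that a change elsewhere on the shared core can move the number beyond the scatter. With nothing bearing on the thiophene itself, the working expectation is a step of no change at the digits printed from compound 1 to compound 3 (within the scatter) that stays within the scatter. Compound 3 is therefore estimated at 9300 nM, with a range from 3500 nM to 25000 nM.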

Compound 3, half-maximal inhibitory concentration: > 50000 nM
Compound 3: a limit, no number (the forecaster's own chance of this, stated with the estimate: 10%); middle value at least 5.3-fold (0.73 log units) from the limit.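

The thiophene position, opposite the ring nitrogen, is not indifferent to how the ring is attached: thiophen-3-yl in place of thiophen-2-yl, with the same heavy atoms and the same counts of donors and acceptors, gives an at least 5.3-fold higher number from compound 1 to compound 3 (0.73 log units; beyond the scatter). In this assay compound 3 gives > 50000 nM, which is a limit of the assay and not a number. The earlier step showed sensitivity only at the hydroxyphenyl groups, whereas this one shows that a change of attachment alone on the thiophene can also carry the series beyond the scatter, though its full size stays unread: the limit of > 50000 nM in this assay, at which 1 of the 3 values shown sits.

The compounds shown leave open whether the same change of attachment would have a similar outcome with the two hydroxyphenyl groups of compound 2. They also leave open what this position would tolerate with a different group, such as furan-2-yl, or with a thiophene ring bearing a carboxylic acid or an aminomethyl group.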